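Ester variation and tolerance on Vero cells

This account rests on a few compounds, and the source may have more. Where it says the series, first, only, none or still open, it means among the compounds named here.

Compound 1 `Nc1ncnc2c1ncn2CC(O)C(=O)OCCO` carries a hydroxyethyl ester on the shared core. In a functional assay on Vero cells (Chlorocebus sabaeus) for cytotoxicity (a lower number here means that less compound is tolerated, a higher number that more compound is tolerated), compound 1 gives > 400 ug/mL, which is a limit of the assay rather than a number. Compound 2 `CCCCOC(=O)C(O)Cn1cnc2c(N)ncnc21` gives 200 ug/mL, and compound 3 `CCCCCOC(=O)C(O)Cn1cnc2c(N)ncnc21` gives 200 ug/mL. The steps were an at least 2.0-fold lower number from compound 1 to compound 2 (0.30 log units; that floor lies within the scatter), an at least 2.0-fold lower number from compound 1 to compound 3 (0.30 log units; that floor lies within the scatter) and no change at the digits printed from compound 2 to compound 3 (within the scatter), so compound 3 stands level with compound 2 at the digits shown.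

Compound 4 `Nc1ncnc2c1ncn2CC(O)C(=O)OCc1ccco1` differs from compound 3 by furan-2-yl in place of butyl on a saturated chain carbon bound to an oxygen next to a carbonyl group. Within the data shown here, only the step from compound 2 to compound 3 bears on this, and it changed nothing beyond the scatter, so the expected step is no change at the digits printed from compound 3 to compound 4 (within the scatter). Compound 4 is therefore estimated at 200 ug/mL, within a range of 100 ug/mL to 400 ug/mL.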

Compound 4, minimum cytotoxic concentration: 40 ug/mL
Beside the measured number, compound 4's estimate is 5.0-fold (0.70 log units) above it; the measured number lies below the stated range.
By their numbers in this assay, from the lowest: compound 4; then compounds 2 and 3 (each within the scatter of the next). At a limit, above all of these: compound 1.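

In this assay, the identity of the group at this position matters in a way that the chain length in compound 2 and compound 3, which stand level, did not show. Furan-2-yl in place of a saturated chain gives a 5.0-fold lower number from compound 3 to compound 4 (0.70 log units; beyond the scatter) and a 5.0-fold lower number from compound 2 to compound 4 (0.70 log units; beyond the scatter), so less compound is tolerated with the ring present. Against the hydroxyethyl ester the step is an at least 10-fold lower number from compound 1 to compound 4 (1.00 log units; beyond the scatter), and this is only a floor, since compound 1 stands at a limit: the limit of > 400 ug/mL in this assay, at which 1 of the 4 values shown sits.

The compounds shown leave open whether any aromatic ring here lowers the number or furan-2-yl alone does. A phenyl or a thiophen-2-yl group in its place would speak to that.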